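Swapping the Pyrrole for Thiophene in a Cytotoxicity Series

A few compounds are considered here, and "the series" means these few. Any claim that something is new, unique, unknown or untested is made for them only; others in the source may bear on it.

Compound 1 `COC1=CC(c2ccco2)=N/C1=C\c1ccc[nH]1`, compound 2 `COC1=CC(c2cccs2)=N/C1=C\c1ccc[nH]1` and compound 3 `COC1=CC(c2cc3ccccc3n2C(=O)OC(C)(C)C)=N/C1=C\c1ccc[nH]1` share one core and were tested in a functional assay on PLC5 cells (Homo sapiens) for cytotoxicity, read by MTT assay; a higher number here means a weaker inhibitor, a lower number a stronger inhibitor. Compound 1 reached only the limit of the assay, > 40000 nM. Compound 2 likewise gave only a limit, > 40000 nM. Compound 3 also stopped at a limit, > 40000 nM. Within the data shown here, the single traceable step, a step that the two limits leave unreadable from compound 1 to compound 2, cannot be read because of the limit of > 40000 nM in this assay, at which 3 of the 3 values shown sit. Compound 4 `COC1=CC(c2cccs2)=N/C1=C\c1cccs1` differs from compound 2 by thiophen-2-yl in place of 1H-pyrrol-2-yl on a double-bonded chain carbon bound to a double-bonded ring carbon. Among the measured compounds shown here, no measured step tells how a change at this position acts, and every value so far is a limit, so no shift beyond the scatter can be expected. Compound 4 is therefore expected to give 60000 nM, within a range from 20000 nM to 200000 nM. This change is expected to amount to a step that the limit leaves unreadable from compound 2 to compound 4.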

Compound 4, half-maximal inhibitory concentration: 25900 nM
The estimate for compound 4 lay 2.3-fold (0.36 log units) above the measured number, and the stated range covers the measured number.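

Among these compounds, compound 4 is the first compound here to give a number rather than a limit in this assay, so the double-bonded chain carbon bound to a double-bonded ring carbon is the first place where a change yields a readable value. Thiophen-2-yl in place of 1H-pyrrol-2-yl gives an at least 1.5-fold lower number from compound 2 to compound 4 (0.18 log units; that floor lies within the scatter). Only that floor can be stated, because compound 2 stands at a limit: the limit of > 40000 nM in this assay, at which 3 of the 4 values shown sit.

On these data alone, whether the hydrogen-bond donor of 1H-pyrrol-2-yl or the sulfur of thiophen-2-yl matters more remains open. So does what a phenyl ring or a carboxylic acid would give at this position.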